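Amide aryl change from compound 2 to compound 3

This account rests on a few compounds, and the source may have more. Where it says the series, first, only, none or still open, it means among the compounds named here.

Compound 1 `O=C(Nc1cc(C(F)(F)F)cc(C(F)(F)F)c1)c1nccc2ccccc12` in a functional assay on NUGC-3 cells (Homo sapiens) for inhibition, read by sulforhodamine B assay, with a stated time of 48 h (a lower number here means a stronger inhibitor of growth, a higher number a weaker inhibitor of growth), reaches only a limit, > 10000 nM. Among the measured compounds shown here, compound 2 `O=C(Nc1ccc(C(F)(F)F)cc1)C1c2ccccc2CCN1C(=O)c1ccc(Cl)cc1` in this assay gives 4200 nM, the sole number in the set, the other value sitting at the limit of > 10000 nM in this assay, at which 1 of the 2 values shown sits. Compound 3 `O=C(Nc1cccc(O)c1)C1c2ccccc2CCN1C(=O)c1ccc(Cl)cc1` differs from compound 2 by 3-hydroxyphenyl in place of 4-(trifluoromethyl)phenyl on an amide-type nitrogen. For the measured compounds named here, no measured step covers this change, so the set offers no direction for it. The expected step is a 1.4-fold higher number from compound 2 to compound 3 (0.15 log units; within the scatter), within the scatter or at most a slight weakening. Compound 3 is expected in this assay at 6000 nM, between 2000 nM and 20000 nM.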

Compound 3, concentration for 50% growth inhibition: > 10000 nM
Compound 3: no number, only a limit; the forecaster's own chance of this, stated with the estimate: 35%; middle value at least 1.6-fold (0.22 log units) away from the limit.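

In this assay, 3-hydroxyphenyl in place of 4-(trifluoromethyl)phenyl on an amide-type nitrogen gives an at least 2.3-fold higher number from compound 2 to compound 3 (0.37 log units; beyond the scatter), so growth inhibition at this position does depend on the aryl group. Compound 3 reaches only a limit, > 10000 nM, so the step has a floor but no measured size: the limit of > 10000 nM in this assay, at which 2 of the 3 values shown sit.

Going by these compounds, how 4-hydroxyphenyl or 3-(trifluoromethyl)phenyl on the same nitrogen would read stays open, so the effects of the group and its place on the ring cannot yet be separated. Also open, on these data alone, is whether an aminophenyl group there would hold or improve on compound 2.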